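The source may hold more compounds than are shown below. What is called first, only, known or untested is meant among the compounds shown, and "the series" means these compounds.

Measured so far in a functional assay on A2780 cells (Homo sapiens) for inhibition, read by sulforhodamine B assay; on this read-out higher numbers stand for weaker inhibition of growth and lower numbers for stronger inhibition of growth:
- compound 1 `Cc1ccc2[nH]c(-c3ccc(-c4ccc(-c5cccc(Cl)c5)cc4)cc3)nc2c1`: 2800 nM
- compound 2 `COc1ccc(-c2ccc(-c3ccc(-c4nc5ccccc5[nH]4)cc3)cc2)cc1`: 100000 nM
- compound 3 `Clc1cccc(-c2ccc(-c3ccc(-c4nc5ccccc5[nH]4)cc3)cc2)c1`: 31100 nM

Compound 1 has the lowest of these three numbers, and both other compounds lie beyond the scatter from it. Compound 4 `Cc1ccc2[nH]c(-c3ccc(-c4ccc(-c5ccc(OC(F)(F)F)cc5)cc4)cc3)nc2c1` shares the core of compound 1 and differs in one place: 4-(trifluoromethoxy)phenyl in place of 3-chlorophenyl on an aromatic carbon.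

The closest measured precedent is a 3.2-fold lower number from compound 2 to compound 3 (0.51 log units; beyond the scatter), a modest step in which 3-chlorophenyl replaces 4-methoxyphenyl. Read in reverse, this precedent points to a higher number when 3-chlorophenyl gives way to 4-methoxyphenyl. The larger step, an 11-fold higher number from compound 1 to compound 3 (1.05 log units; beyond the scatter), concerns the methyl group. Compound 4 keeps that methyl, so this step does not bear on the change itself, but it supports taking compound 1 rather than compound 3 as the starting point.

Going by the values given here, no measured compound carries 4-(trifluoromethoxy)phenyl, and only one pair speaks to this exchange, so the transfer from 4-methoxyphenyl is uncertain. A modest rise in this assay is therefore expected, and the expected step is a 2.0-fold higher number from compound 1 to compound 4 (0.29 log units; within the scatter). Compound 4 is estimated at 5500 nM, with an expected range from 1600 nM to 20000 nM.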

Compound 4, concentration for 50% growth inhibition: 12300 nM
Compound 4: middle estimate off by 2.2-fold (0.35 log units), on the low side; low and high end bracket the measured number.
By their numbers in this assay, from the lowest: compound 1; then compound 4; then compound 3; then compound 2.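

In this assay the exchange of 3-chlorophenyl for 4-(trifluoromethoxy)phenyl on the methyl-bearing core gives a 4.4-fold higher number from compound 1 to compound 4 (0.64 log units; beyond the scatter) and so extends the picture to a second core and a new entering group. Together with a 3.2-fold lower number from compound 2 to compound 3 (0.51 log units; beyond the scatter) on the core without the methyl, both pairs now give the lower number to the compound with 3-chlorophenyl, and no compound shown goes against this, although the pairs differ in both core and the group exchanged with 3-chlorophenyl, so the sizes of their steps do not measure the same change. No measurement shown here accounts for the rise in the number on this exchange.

Each pair changes the substituent on the terminal ring and its place on that ring together, so the compounds shown do not tell whether the chlorine, its place or the oxygen-linked group decides the outcome. On these data alone, how this position responds to an unsubstituted phenyl, or to a phenyl carrying an amine or a carboxylic acid, stays open, as does whether the preference for 3-chlorophenyl holds beyond these two pairs.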